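A few compounds are considered here, and "the series" means these few. Any claim that something is new, unique, unknown or untested is made for them only; others in the source may bear on it.

Three compounds of the series have so far been run in a functional assay on MCF7 cells (Homo sapiens) for antiproliferative activity, read by MTT assay, with a stated time of 72 h; a higher number here means a weaker inhibitor, a lower number a stronger inhibitor. Compound 1 `CC(C)/C=C/C(=O)Nc1cc2c(N3CCc4ccccc43)ncnc2cc1O[C@@H]1CCOC1` gives 9880 nM. Compound 2 `CCC/C=C/C(=O)Nc1cc2c(N3CCc4ccccc43)ncnc2cc1O[C@@H]1CCOC1` gives 4550 nM; the change between them is propyl in place of isopropyl on a double-bonded chain carbon bound to a double-bonded chain carbon, and it made a 2.2-fold lower number from compound 1 to compound 2 (0.34 log units; beyond the scatter). Compound 3 `COc1cc2ncnc(N3CCCc4ccccc43)c2cc1NC(=O)/C=C/C(C)C`, on a different core, gives 4290 nM; the difference between the cores of compound 1 and compound 3 is not broken down here. The values of compound 3 and compound 2 lie within the scatter of each other, so no order between them is claimed.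

Compound 4 `CCC/C=C/C(=O)Nc1cc2c(N3CCCc4ccccc43)ncnc2cc1OC` has not yet been measured. It stands to compound 3 as compound 2 stands to compound 1: the change is propyl in place of isopropyl on a double-bonded chain carbon bound to a double-bonded chain carbon, the same change at the same place, now on the core of compound 3. Within the data shown here, the one earlier instance, a 2.2-fold lower number from compound 1 to compound 2 (0.34 log units; beyond the scatter), lay beyond the scatter, though a single pair on another core is thin ground for carrying it over. Assuming the same direction and a similar size, the step expected here is a 2.0-fold lower number from compound 3 to compound 4 (0.31 log units; beyond the scatter). Compound 4 is accordingly estimated at 2100 nM, with a range from 1000 nM to 4500 nM that allows for the step not transferring fully to this core.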

Compound 4, half-maximal inhibitory concentration: 1210 nM
Beside the measured number, compound 4's estimate is 1.7-fold (0.24 log units) above it; the range from low to high includes it.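

In this assay, propyl in place of isopropyl on a double-bonded chain carbon bound to a double-bonded chain carbon keeps its direction on the core of compound 3, with a 3.5-fold lower number from compound 3 to compound 4 (0.55 log units; beyond the scatter) on that core. Set beside the earlier step, the two sizes cannot be told apart: the same change on two cores in this assay, a 2.2-fold lower number (0.34 log units; beyond the scatter) from compound 1 to compound 2 and a 3.5-fold lower number (0.55 log units; beyond the scatter) from compound 3 to compound 4, 1.6-fold (0.21 log units) apart, within the scatter of two such steps.
The change therefore carries over between these two cores in direction and, within the scatter, in size, but two pairs cannot show that it would hold on any further core, and a small dependence on the core is neither shown nor excluded.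

Going by these compounds, only isopropyl and propyl appear at this place, so it remains open whether a longer chain such as pentyl, or a chain ending in a dimethylamino group, would follow the same direction. The difference between the core of compound 1 and the core of compound 3 also remains unresolved, so its separate parts cannot be assigned any share of the values.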